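Swapping the aryl group on a nitrophenyl antiproliferative lead

A few compounds are considered here, and "the series" means these few. Any claim that something is new, unique, unknown or untested is made for them only; others in the source may bear on it.

Compound 1 `COc1ccc(-c2ccnc(Nc3ccc([N+](=O)[O-])cc3)n2)cc1`: 980 nM
Compound 2 `COc1ccc(-c2ccnc(Nc3ccc(Cl)cc3Cl)n2)cc1`: 23000 nM
Compound 3 `COc1ccc(-c2ccnc(Nc3cccc(OC)c3)n2)cc1`: 550 nM

All three were measured in a functional assay on HeLa cells (Homo sapiens) for antiproliferative activity, read by MTT assay; a higher number here means a weaker inhibitor, a lower number a stronger inhibitor. Compound 1 lies within the usual scatter of compound 3, while compound 2 shows a much higher number, well beyond the scatter. Compound 4 `O=[N+]([O-])c1ccc(Nc2nccc(-c3ccc(Cl)c(Cl)c3)n2)cc1` differs from compound 1 in one place: 3,4-dichlorophenyl in place of 4-methoxyphenyl on an aromatic carbon. Among the measured compounds shown here, no measured pair shows this change directly. For the measured compounds named here, the only measured compound carrying chlorine is compound 2, at 23000 nM, and its chlorines sit on a different part of the molecule, so it is a weak guide. A moderate move toward weaker inhibition in this assay is expected, an estimated 2.6-fold higher number from compound 1 to compound 4 (0.41 log units; beyond the scatter). For compound 4 the estimated value is 2500 nM, with an expected range of 400 nM to 15000 nM.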

Compound 4, half-maximal inhibitory concentration: 1840 nM
Estimate against measurement, compound 4: 1.4-fold (0.13 log units) above; the measured number falls inside the stated range.
By their numbers in this assay, from the lowest: compounds 3, 1 and 4 (each within the scatter of the next, the first and the last beyond it); then compound 2.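

Among the compounds shown here, all earlier compounds kept 4-methoxyphenyl, so this is the first look at this position. In this assay, 3,4-dichlorophenyl in place of 4-methoxyphenyl gives a 1.9-fold higher number from compound 1 to compound 4 (0.27 log units; within the scatter), so this pair shows that the position takes an all-carbon-and-chlorine aryl group without losing the oxygen-bearing group's level of activity beyond the scatter. Nothing measured here explains this result.

As far as these compounds go, whether a smaller group on this carbon, such as an amine or a carboxylic acid, would fit equally well stays open. So does whether the same swap gives a similar result with the other aniline groups of compound 2 and compound 3.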